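Replacing 4-chlorobenzyl with carboxy: working notes

A few compounds are considered here, and "the series" means these few. Any claim that something is new, unique, unknown or untested is made for them only; others in the source may bear on it.

Measured in a functional assay on P388 cells (Mus musculus) for cytotoxicity; a lower number here means a stronger inhibitor, a higher number a weaker inhibitor:
- compound 1 `Cc1cc(-c2c(F)cc3c(=O)c(Cc4cccc(O)c4)cn(C4CC4)c3c2F)cc(C)n1`: 2200 nM
- compound 2 `Cc1cc(-c2c(F)cc3c(=O)c(Cc4ccc(Cl)cc4)cn(C4CC4)c3c2F)cc(C)n1`: 20000 nM
- compound 3 `Cc1cc(-c2c(F)cc3c(=O)c(Cc4cccc(O)c4O)cn(C4CC4)c3c2F)cc(C)n1`: 880 nM

Of the three, compound 2 has the highest number in this assay, at 20000 nM. Compound 4 `Cc1cc(-c2c(F)cc3c(=O)c(C(=O)O)cn(C4CC4)c3c2F)cc(C)n1` carries carboxy in place of 4-chlorobenzyl on an aromatic carbon.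

Two measured steps start from or end at the same place on the core. One is a 9.1-fold higher number from compound 1 to compound 2 (0.96 log units; beyond the scatter), a modest step. The other is a 23-fold lower number from compound 2 to compound 3 (1.36 log units; beyond the scatter), a large one. Both show compound 2 with the higher number, so the two other groups measured at this place both do better than 4-chlorobenzyl. Among the compounds with values here, neither step removes the aromatic ring from this position, however, and no measured compound has carboxy here, so the evidence is indirect.

A modest move to a lower number is therefore expected, with wide uncertainty. The expected change is a 3.3-fold lower number from compound 2 to compound 4 (0.52 log units; beyond the scatter). For compound 4 the estimated value is 6000 nM, with an expected range of 1200 nM to 30000 nM.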

Compound 4, half-maximal inhibitory concentration: 29000 nM
For compound 4 the middle estimate is 4.8-fold (0.68 log units) below the measured one, within the range that was stated.
By their numbers in this assay, from the lowest: compound 3; then compound 1; then compounds 2 and 4 (each within the scatter of the next).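

In this assay, swapping 4-chlorobenzyl for carboxy gives no separable change (a 1.5-fold higher number from compound 2 to compound 4 (0.16 log units; within the scatter)), so a group without an aromatic ring sits level with 4-chlorobenzyl at this position, and the ring alone does not set the number. Both hydroxy-bearing benzyl groups stand clearly apart from carboxy (a 13-fold higher number from compound 1 to compound 4 (1.12 log units; beyond the scatter) and a 33-fold higher number from compound 3 to compound 4 (1.52 log units; beyond the scatter)), so among the four groups shown, the lower numbers belong only to the benzyl groups carrying hydroxy. Nothing available accounts for these differences.

Still open, from the compounds shown here alone, is whether the hydroxy groups need the benzyl frame, which a hydroxymethyl group or an unsubstituted benzyl at this position would help to test. A methyl ester or a primary amide in place of carboxy would show whether the level seen here is particular to the carboxylic acid.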